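The source may report more compounds than this note shows. Statements on the series, on what has been measured and on what is new or still open speak of the compounds shown alone.

In a functional assay on HeLa cells (Homo sapiens) for inhibition, read by MTT assay, with a stated time of 72 h (on this read-out higher numbers stand for weaker inhibition and lower numbers for stronger inhibition), compound 1 `Nc1nc2cc(-c3nn(CCCC(=O)NO)c4ncnc(N)c34)ccc2o1` gives > 150000 nM as a limit of the assay and not as a number. Compound 1 therefore stands at the limit of > 150000 nM in this assay, at which 1 of the 3 values shown sits, and has no exact rank. Compound 2 `Nc1ncnc2c1c(-c1cnc3[nH]ccc3c1)nn2CCCCCCCCCC(=O)NO` gives a measured 7560 nM in this assay while compound 3 `Nc1ncnc2c1c(-c1cnc3[nH]ccc3c1)nn2CCC(=O)NO` has the entry "not determined" (no result reported) and offers no comparison.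

Compound 4 `Nc1nc2cc(-c3nn(CC(=O)NO)c4ncnc(N)c34)ccc2o1` differs from compound 1 on a saturated chain carbon bound to an aromatic nitrogen, where hydroxycarbamoyl stands in place of 2-(hydroxycarbamoyl)ethyl hydroxycarbamoyl in place of 2-(hydroxycarbamoyl)ethyl on a saturated chain carbon bound to an aromatic nitrogen and 3-(hydroxycarbamoyl)propyl thus becomes (hydroxycarbamoyl)methyl. For the measured compounds named here, no measured step between two compounds sizes this change in this assay and so no shift beyond the scatter is expected in either direction. The expected step of a number no higher from compound 1 to compound 4 (the limit leaves the size open) is therefore close to nil, and compound 4 may well be reported only as a limit too. Compound 4 is estimated at 150000 nM with an expected range from 70000 nM to 350000 nM in this assay on this reading.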

Compound 4, half-maximal inhibitory concentration: > 150000 nM
Compound 4 was reported as a limit; the forecaster's own chance of this, stated with the estimate: 75%; the middle value lies on the limit itself.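

Compound 1 and compound 4 are both reported only as a limit in this assay, so no step between them can be read: the limit of > 150000 nM in this assay, at which 2 of the 4 values shown sit.

The compounds shown leave open whether 3-(hydroxycarbamoyl)propyl and (hydroxycarbamoyl)methyl differ at all in their effect on the shared core in this assay.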